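Swapping fluoro for cyano on compound 3

A few compounds are considered here, and "the series" means these few. Any claim that something is new, unique, unknown or untested is made for them only; others in the source may bear on it.

Three measured compounds share one core and differ in the group on a saturated chain carbon bound to an oxygen. In a physicochemical assay for lipophilicity, using the shake flask method, in phosphate buffer, measured as octanol-water partition, at pH 7.4 (a higher number here means a more lipophilic compound, a lower number a more polar compound), compound 1 (`C[C@@H]1CN(C(=O)OC(C)(C)C)CCN1c1ncc(OCC2CCN(S(C)(=O)=O)CC2)cn1`) gives 3.5, and compound 3 (`C[C@@H]1CN(C(=O)OC(C)(C)C)CCN1c1ncc(OCc2ccc(S(C)(=O)=O)cc2F)cn1`) gives 3.7, so these two numbers lie within the scatter of each other. Compound 2 (`C[C@@H]1CN(C(=O)OC(C)(C)C)CCN1c1ncc(OCc2ccc(C#N)cc2)cn1`) gives > 3.6, which is a limit and not a number.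

Compound 4 (`C[C@@H]1CN(C(=O)OC(C)(C)C)CCN1c1ncc(OCc2ccc(S(C)(=O)=O)cc2C#N)cn1`) differs from compound 3 by one change, cyano in place of fluoro on an aromatic carbon, ortho to a large group and meta to a methylsulfonyl group.

Going by the values given here, no measured step makes this exchange, so the evidence is indirect. Replacing a whole group gave a number 0.20 log units higher from compound 1 to compound 3 (within the scatter). Going by these compounds, a second replacement, to a group that also carries cyano, gave a number at least 0.10 log units higher from compound 1 to compound 2 (that floor lies within the scatter), but that step rests on a limit, so its full size stays open. On this thin basis, no step beyond the scatter is expected in this assay. The estimated step is a number 0.20 log units lower from compound 3 to compound 4 (within the scatter). Compound 4 is expected at 3.5, with an estimated range from 3.1 to 3.9.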

Compound 4, distribution coefficient: 3.3
Compound 4: the middle estimate sits 0.20 log units above what was measured; low and high end bracket the measured number.
By their numbers in this assay, from the lowest: compounds 4, 1 and 3 (each within the scatter of the next, the first and the last beyond it).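

Going by these compounds alone, this is the first measured exchange made at this one aromatic carbon, ortho to a large group and meta to a methylsulfonyl group. In this assay, cyano in place of fluoro gives a number 0.40 log units lower from compound 3 to compound 4 (beyond the scatter). The earlier replacement of a whole group, a number 0.20 log units higher from compound 1 to compound 3 (within the scatter), stayed inside the scatter, whereas this exchange of a single fluorine for a cyano group of 2 heavy atoms does not, so in this pair a small change at one ring carbon moves the read-out further than that larger replacement did, although the data do not give the reason.

The compounds shown leave open how a chlorine, a methoxy group, an amine or a carboxylic acid on this same aromatic carbon would compare with fluoro and cyano, and whether the step would hold on a ring without the methylsulfonyl group. Compound 2 gives > 3.6, which is a limit and not a number, so the steps that involve it cannot be read: the limit of > 3.6 in this assay, at which 1 of the 4 values shown sits.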